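Changing the amine end of compound 1

A few compounds are considered here, and "the series" means these few. Any claim that something is new, unique, unknown or untested is made for them only; others in the source may bear on it.

Measured in a functional assay on HT-29 cells (Homo sapiens) for inhibition, read by CellTiter-Glo, with a stated time of 72 h; on this read-out higher numbers stand for lower toxicity in this test and lower numbers for higher toxicity in this test:
compound 1 `CC1=C(CC(=O)NCCN(C)C)c2cc(F)ccc2/C1=C\c1nc2ccccc2s1`: 1570 nM
compound 2 `CC1=C(CC(=O)NCCN(C)C)c2cc(F)ccc2/C1=C\c1ccncc1`: 6890 nM
compound 3 `CC1=C(CC(=O)NCCN(C)C)c2cc(F)ccc2/C1=C\c1ccc(S(C)(=O)=O)cc1`: 12700 nM

Compound 1 has the lowest number of the three, which means the highest toxicity in this test. Compound 4 `CC1=C(CC(=O)NCCN2CCCC2)c2cc(F)ccc2/C1=C\c1nc2ccccc2s1` differs from it in one place: pyrrolidin-1-yl in place of dimethylamino on a saturated chain carbon, two bonds along the chain from an amide-type nitrogen.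

The measured steps all replace a different group, 1,3-benzothiazol-2-yl or pyridin-4-yl. a 4.4-fold higher number from compound 1 to compound 2 (0.64 log units; beyond the scatter) and an 8.1-fold higher number from compound 1 to compound 3 (0.91 log units; beyond the scatter) lie beyond the scatter, while a 1.8-fold higher number from compound 2 to compound 3 (0.27 log units; within the scatter) lies within it. None of them tests the dimethylamino group, so they bear only indirectly, and no step beyond the scatter is expected in this assay. The expected change is a 1.0-fold lower number from compound 1 to compound 4 (0.02 log units; within the scatter). Compound 4 is estimated at 1500 nM, with an expected range of 700 nM to 3300 nM.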

Compound 4, half-maximal cytotoxic concentration: 1210 nM
Compound 4: the middle estimate sits 1.2-fold (0.09 log units) above what was measured; measured number inside the range.
By their numbers in this assay, from the lowest: compounds 4 and 1 (each within the scatter of the next); then compounds 2 and 3 (each within the scatter of the next).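

Among the compounds shown here, this is the first test of the amine end of compound 1. In this assay, replacing dimethylamino with pyrrolidin-1-yl gives a 1.3-fold lower number from compound 1 to compound 4 (0.11 log units; within the scatter) and so stays within the scatter, which means that adding a ring and more carbon on this saturated chain carbon leaves the two compounds indistinguishable. Nothing measured here offers an explanation for this result. Still open, going by these compounds, is how a morpholine, a piperidine or a primary amine would read at this place, and what a longer chain before the amine would do.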